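This account rests on a few compounds, and the source may have more. Where it says the series, first, only, none or still open, it means among the compounds named here.

Going by the values given here, compound 3 `COc1cc(N)c(Cl)cc1C(=O)NC1CCN(CCCCCCCCN2C(=O)c3ccccc3C2=O)CC1` carries the only number in the set: in a functional assay on HEK293 cells for activation of 5-hydroxytryptamine receptor 4 (Homo sapiens), read by cAMP accumulation (a higher number here means a larger maximal response, a lower number a smaller maximal response), compound 3 gives 89%. Compound 1 `CCN1CCC(NC(=O)c2cc(Cl)c(N)cc2OC)CC1` stands at a limit of this assay, > 100%, which is a limit and not a number. Compound 2 `COc1cc(N)c(Cl)cc1C(=O)NC1CCN(CCCCCO)CC1` likewise stands at a limit, > 100%. The step that the two limits leave unreadable from compound 1 to compound 2 cannot be read, and the limit of > 100% in this assay, at which 2 of the 3 values shown sit, holds two of the three values. Compound 4 `COc1cc(N)c(Cl)cc1C(=O)NC1CCN(CCCCCCCCS(=O)(=O)O)CC1` differs from compound 3 by a group of 4 heavy atoms (3 oxygen, 1 sulfur; no ring) in place of a group of 11 heavy atoms (8 carbon, 1 nitrogen, 2 oxygen; one five-membered non-aromatic ring with 1 hetero atom, one six-membered aromatic ring of carbon only), on a saturated chain carbon, eight bonds along the chain from an amine nitrogen in a ring. Among the compounds with values here, no measured step covers a change of this kind, so the measured steps give no direction, and nothing beyond the usual scatter is expected. Compound 4 is expected to give 90% in this assay, within 70% to 110%. The step of a number 1 percentage points higher from compound 3 to compound 4 (within the scatter) is estimated to lie within the scatter.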

Compound 4, intrinsic activity: the largest response reached, in percent of the reference agonist's: > 100%
Compound 4 gave a limit, no number; the forecaster's own chance of this, stated with the estimate: 25%; middle value at least 10 percentage points away from the limit.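

In this assay, going by these compounds alone, the end of the eight-carbon chain is the first place where a change gives a readable step: sulfo in place of the group of 11 heavy atoms gives a number at least 11 percentage points higher from compound 3 to compound 4 (beyond the scatter). Compound 4 stands at a limit, > 100%, which is not a number. The steps from compound 1 and from compound 2 to compound 4 cannot be read: the limit of > 100% in this assay, at which 3 of the 4 values shown sit.

As far as these compounds go, whether a carboxylic acid or an amine at the same chain end would match the sulfo group remains open. So does the result of a longer chain carrying sulfo.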